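Adding a Propyl Chain to a Second Fused Core

The source may hold more compounds than are shown below. What is called first, only, known or untested is meant among the compounds shown, and "the series" means these compounds.

Measured so far:
compound 1, `CCCc1nc(C)c2cnn(C)c(=O)n12`: 20000 nM
compound 2, `CCCc1nn(C)c(=O)n2c(CCC)nc(C)c12`: 18000 nM
compound 3, `CCCc1nc(C)c2ccnc(Nc3cc[nH]n3)n12`: 25000 nM

These values come from a functional assay for inhibition, with Homo sapiens as the target; on this read-out lower numbers stand for stronger inhibition and higher numbers for weaker inhibition. Compound 2 differs from compound 1 by propyl in place of hydrogen on an aromatic carbon, and this gave a 1.1-fold lower number from compound 1 to compound 2 (0.05 log units; within the scatter). Compound 3 carries a different core; the difference between the two cores is not broken down here, and its value and that of compound 1 lie within the scatter of each other.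

Compound 4, `CCCc1cnc(Nc2cc[nH]n2)n2c(CCC)nc(C)c12`, differs from compound 3 by propyl in place of hydrogen on an aromatic carbon. This is the same kind of change as from compound 1 to compound 2, though the surroundings differ: here the six-membered aromatic ring holds 2 nitrogen and the place is para to a (1H-pyrazol-3-yl)amino group, whereas in compound 1 the ring holds 3 nitrogen and the place is next to the ring nitrogen, meta to a methyl group and para to a group of 1 heavy atom.

Because a 1.1-fold lower number from compound 1 to compound 2 (0.05 log units; within the scatter) lay within the scatter, the step of a 1.1-fold lower number from compound 3 to compound 4 (0.06 log units; within the scatter) is expected to be equally small in this assay. Compound 4 is therefore estimated at 22000 nM, likely between 9000 nM and 55000 nM.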

Compound 4, half-maximal inhibitory concentration: > 48000 nM
Compound 4 was reported as a limit; the forecaster's own chance of this, stated with the estimate: 15%; middle value at least 2.1-fold (0.33 log units) from the limit.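

In this assay, compound 4 gives > 48000 nM, which is a limit of the assay and not a number. Placing the propyl chain on the core of compound 3 gives an at least 1.9-fold higher number from compound 3 to compound 4 (0.28 log units; that floor lies within the scatter), so this core shows no gain in inhibition from the change, but the true size of the step stays unknown. Whether the change behaves differently on the two cores cannot be said: the same change on two cores in this assay, a 1.1-fold lower number (0.05 log units; within the scatter) from compound 1 to compound 2 and an at least 1.9-fold higher number (0.28 log units; that floor lies within the scatter) from compound 3 to compound 4; the limit leaves it open whether they differ

The compounds shown leave open how a smaller ethyl group, or an amine, would read on the same aromatic carbon. They also leave open how far the value of compound 4 lies beyond its limit.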